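Ethoxycarbonyl to benzyloxycarbonyl on the shared core

The source may report more compounds than this note shows. Statements on the series, on what has been measured and on what is new or still open speak of the compounds shown alone.

Compound 1 (`CCOC(=O)N1N=C(c2ccccc2)CC1c1cc(OC)c(OC)c(OC)c1`) reads 8920 nM in a functional assay on HT-29 cells (Homo sapiens) for antiproliferative activity, read by MTT assay, with a stated time of 48 h (a higher number here means a weaker inhibitor of growth, a lower number a stronger inhibitor of growth), and compound 2 (`COC(=O)N1N=C(c2cccc(OC)c2)CC1c1cc(OC)c(OC)c(OC)c1`) reads 1300 nM in the same test. Compound 3 (`CCOC(=O)N1N=C(c2cccc(OC)c2)CC1c1cc(OC)c(OC)c(OC)c1`) reads 7860 nM and holds the second highest of the three numbers, level with compound 1 and well clear of compound 2. Methoxy in place of hydrogen on an aromatic carbon gives a 1.1-fold lower number from compound 1 to compound 3 (0.05 log units; within the scatter) and offers no guide to the next change. Methyl in place of hydrogen on a saturated chain carbon bound to an oxygen next to a carbonyl group gives a 6.0-fold higher number from compound 2 to compound 3 (0.78 log units; beyond the scatter) and is the only measured step at that place.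

Compound 4 (`COc1cccc(C2=NN(C(=O)OCc3ccccc3)C(c3cc(OC)c(OC)c(OC)c3)C2)c1`) differs from compound 3 by phenyl in place of methyl on a saturated chain carbon bound to an oxygen next to a carbonyl group with phenyl in place of methyl at this same place. Among the measured compounds shown here, the single earlier step there went towards a higher number, but one step sets no trend, and a phenyl group is a much larger change than a methyl group. A modest further rise is therefore expected, with wide uncertainty, and the estimate is a 1.4-fold higher number from compound 3 to compound 4 (0.15 log units; within the scatter) in this assay on this thin evidence. For compound 4 the estimate is 11000 nM with an expected range from 3500 nM to 30000 nM in this test.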

Compound 4, concentration for 50% growth inhibition: > 10000 nM
Compound 4 gave a limit, no number; the forecaster's own chance of this, stated with the estimate: 10%; the middle value lies beyond the limit too.
By their numbers in this assay, from the lowest: compound 2; then compounds 3 and 1 (each within the scatter of the next). At a limit, above all of these: compound 4.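

Compound 4 reads > 10000 nM in this assay, which is a limit of the assay and not a number. On the saturated chain carbon bound to an oxygen next to a carbonyl group, phenyl in place of hydrogen gives an at least 7.6-fold higher number from compound 2 to compound 4 (0.88 log units; beyond the scatter), so this place now has two substituents, methyl and phenyl, and with neither does the number come back to that of compound 2, 1300 nM. Phenyl in place of methyl gives an at least 1.2-fold higher number from compound 3 to compound 4 (0.10 log units; that floor lies within the scatter), and that floor lies within the scatter, so the series does not yet show whether ethoxycarbonyl to benzyloxycarbonyl costs anything further or how large the step really is: the limit of > 10000 nM in this assay, at which 1 of the 4 values shown sits.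

Open, as far as these compounds go, is whether any group at this place other than hydrogen keeps the number of compound 2, for instance a longer chain such as propyl, or a benzyl ring carrying an amine or a carboxylic acid. Also open, from the compounds shown here alone, is whether the step from ethoxycarbonyl to benzyloxycarbonyl reads the same on the core of compound 1, whose aromatic ring has no methoxy group.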